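The source may hold more compounds than are shown below. What is called first, only, known or untested is meant among the compounds shown, and "the series" means these compounds.

Measured so far in an assay on CV-1 cells for activation of retinoic acid receptor gamma (Homo sapiens); on this read-out lower numbers stand for an effect already at smaller amounts and higher numbers for an effect only at larger amounts of compound:
compound 1 `C/C(=C\c1ccc(C(=O)O)cc1)c1ccc2c(c1)C(C)(C)CCO2` – 200 nM
compound 2 `C/C(=C\c1ccc(C(=O)O)cc1)c1ccc2c(c1)C(C)(C)CO2` – 460 nM
compound 3 `C/C(=C\c1ccc(C(=O)O)cc1)c1ccc2c(c1)C(C)(C)CS2` – 30 nM

In this assay compound 1 holds the second highest of the three numbers. Compound 2 lies nearest to it with a higher number, a gap beyond the scatter; compound 3 lies furthest, with a lower number, also beyond the scatter. Compound 4 `COC(=O)c1ccc(/C=C(\C)c2ccc3c(c2)C(C)(C)CCO3)cc1` differs from compound 1 by methyl in place of hydrogen on an oxygen next to a carbonyl group. For the measured compounds named here, no pair of measured compounds shows this change, so its effect cannot be read from the measured set; all three measured compounds carry the carboxy group. Compound 4 is nevertheless expected to give a higher number, a step estimated at a 15-fold higher number from compound 1 to compound 4 (1.18 log units; beyond the scatter). Compound 4 is expected at 3000 nM, within a range from 600 nM to 20000 nM.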

Compound 4, half-maximal effective concentration: 330 nM
Beside the measured number, compound 4's estimate is 9.1-fold (0.96 log units) above it, and the stated range ends above it.
By their numbers in this assay, from the lowest: compound 3; then compounds 1, 4 and 2 (each within the scatter of the next, the first and the last beyond it).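

For the compounds shown here, replacing carboxy with methoxycarbonyl gives in this assay a 1.7-fold higher number from compound 1 to compound 4 (0.22 log units; within the scatter), the first view of this position, since all the earlier compounds carry the carboxy group. On the core of compound 1, then, methyl can take the place of the hydrogen on this oxygen without a change beyond the scatter. Nothing at hand offers an explanation for this result.

From the compounds shown here alone, whether a longer chain such as ethyl, or an amide in place of the methoxycarbonyl, would give a similar number remains open. So does whether the same change would give a step of similar size on the cores of compound 2 and compound 3.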